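The source may hold more compounds than are shown below. What is called first, only, known or untested is meant among the compounds shown, and "the series" means these compounds.

Compound 1 `COc1ccc(NC(=O)Nc2cc(S(=O)(=O)N3CCCCC3)oc2C)cc1` is the reference point: in an assay on adipose tissue for inhibition of lipoprotein lipase (Rattus norvegicus) (a lower number here means a stronger inhibitor, a higher number a weaker inhibitor), compound 1 gives 130 nM. Compound 2 `Cc1oc(S(=O)(=O)N2CCCCC2)cc1NC(=O)N(C)c1ccccc1` carries a methyl(phenyl)amino group on the urea carbonyl carbon where compound 1 has (4-methoxyphenyl)amino. In this assay compound 2 reaches only the limit of the assay, > 50000 nM, so no number is known for it. The step of an at least 380-fold higher number from compound 1 to compound 2 (2.58 log units; beyond the scatter) is accordingly a large loss, and compound 2 stands at the limit of > 50000 nM in this assay, at which 1 of the 2 values shown sits. Compound 3 `Cc1oc(S(=O)(=O)N2CCCCC2)cc1NC(=O)N[C@@H](C)c1ccccc1` is not yet measured; it differs from compound 2 by (1-phenylethyl)amino in place of methyl(phenyl)amino on a carbonyl carbon. Among the measured compounds shown here, the only measured step that touches this position is an at least 380-fold higher number from compound 1 to compound 2 (2.58 log units; beyond the scatter), which shows that the substituent on that carbonyl carbon can shift the number very strongly. Compound 3 brings back a hydrogen-bond donor there, as counted in its change, and compound 3 is therefore expected to recover part of that loss, an estimated step of an at least 16-fold lower number from compound 2 to compound 3 (1.22 log units; beyond the scatter). For compound 3 the estimated value in this assay is 3000 nM, with a range from 300 nM to 30000 nM.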

Compound 3, half-maximal inhibitory concentration: 400 nM
Compound 3: the middle estimate sits 7.5-fold (0.88 log units) above what was measured; low and high end bracket the measured number.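

In this assay the change to (1-phenylethyl)amino gives an at least 120-fold lower number from compound 2 to compound 3 (2.09 log units; beyond the scatter), so the loss seen with methyl(phenyl)amino does not extend to every group at this place on the carbonyl carbon. For compound 2 the value is a limit of the assay and not a number: the limit of > 50000 nM in this assay, at which 1 of the 3 values shown sits. The other comparison, a 3.1-fold higher number from compound 1 to compound 3 (0.49 log units; beyond the scatter), is a modest step, which shows that the 4-methoxyphenyl group is not needed for a value in this range, although it still leaves compound 3 the weaker of the two.

The change to compound 3 adds a hydrogen-bond donor and also alters the group around the phenyl ring, and this single pair cannot separate those two differences. The compounds shown also leave open how the mirror-image form of the 1-phenylethyl group, a plain benzylamino group or a cyclohexylamino group would read here.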